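The source may hold more compounds than are shown below. What is called first, only, known or untested is meant among the compounds shown, and "the series" means these compounds.

Working notes on the series in an ADME assay on MT4 cells (Homo sapiens) for cytotoxicity, with a stated time of 5 days; on this read-out higher numbers stand for lower toxicity in this test and lower numbers for higher toxicity in this test. In this assay compound 1 `O=C(CCl)Nc1ccc(Cl)cc1NS(=O)(=O)c1cc(F)cc(F)c1` gives 179000 nM. Compound 2 `O=C1CN(S(=O)(=O)c2cc(F)cc(F)c2)c2cc(Cl)ccc2N1` gives 187000 nM, which lies within the scatter of compound 1. Compound 3 `O=C1CN(S(=O)(=O)c2c(Cl)cccc2Cl)c2cc(Cl)ccc2N1` gives only a limit, > 319000 nM, and not a number. Among the measured compounds shown here, compound 1 and compound 2 therefore hold the only two numbers, and they cannot be told apart.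

The next compound to be read is compound 4 `Cc1cc(C)cc(S(=O)(=O)Nc2cc(Cl)ccc2NC(=O)CCl)c1`. It carries 3,5-dimethylphenyl in place of 3,5-difluorophenyl on a sulfonyl sulfur, and the rest of compound 1 is unchanged (3,5-dimethylphenyl in place of 3,5-difluorophenyl on a sulfonyl sulfur). For the measured compounds named here, no measured pair isolates this exchange, so the expectation rests on compound 1 at 179000 nM. No step beyond the scatter is expected in this assay, and no direction is favoured. The estimated step is a 1.1-fold lower number from compound 1 to compound 4 (0.02 log units; within the scatter). Compound 4 is estimated at 170000 nM, with an expected range of 70000 nM to 320000 nM.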

Compound 4, half-maximal cytotoxic concentration: 35100 nM
For compound 4 the middle estimate is 4.8-fold (0.69 log units) above the measured one; measured number outside the range, below it.
By their numbers in this assay, from the lowest: compound 4; then compounds 1 and 2 (each within the scatter of the next). At a limit, above all of these: compound 3.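

In this assay, among the compounds shown here, the exchange of 3,5-difluorophenyl for 3,5-dimethylphenyl on a sulfonyl sulfur gives a 5.1-fold lower number from compound 1 to compound 4 (0.71 log units; beyond the scatter), the first step that can be read as beyond the scatter. With the rest of compound 1 unchanged, the group on this sulfur is therefore not silent in this test, and this exchange moves the read-out towards higher toxicity in this test. No measured property of either group bears on this step, so it stands as a single observation without an explanation.

From the compounds shown here alone, whether the same exchange has a similar effect when made on compound 2 remains open. Also open, going by these compounds, is where an unsubstituted phenyl, a 3,5-dimethoxyphenyl or a group carrying an amine on the same sulfur would fall relative to compound 1 and compound 4.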